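Replacing an Amide by a Dichlorophenyl Urea

A few compounds are considered here, and "the series" means these few. Any claim that something is new, unique, unknown or untested is made for them only; others in the source may bear on it.

Of the compounds shown here, three built on one shared core have been tested in a functional assay on 786-0 cells (Homo sapiens) for inhibition, read by sulforhodamine B assay, with a stated time of 48 h; on this read-out lower numbers stand for higher toxicity in this test and higher numbers for lower toxicity in this test. Compound 1 `O=C(Nc1cccc(-n2cc(-c3ccncc3)c(-c3ccc(Cl)c(O)c3)n2)c1)Nc1cccc(C(F)(F)F)c1` reaches only a limit in this assay, > 32500 nM, which is a boundary of the test rather than a number (the limit of > 32500 nM in this assay, at which 1 of the 3 values shown sits). Among the compounds with values here, compound 2 `COc1cc(-c2nn(-c3cccc(NC(=O)Nc4cc(C(F)(F)F)cc(C(F)(F)F)c4)c3)cc2-c2ccncc2)ccc1Cl` is the one compound with a measured number: in this assay compound 2 gives 4310 nM. Compound 3 `COc1cc(-c2nn(-c3cccc(NC(=O)c4cccc(C(F)(F)F)c4)c3)cc2-c2ccncc2)ccc1Cl` carries a plain amide where compound 2 carries a carbamoyl group. Compound 3 also reaches only a limit in this assay, > 50000 nM, again a boundary of the test rather than a number (the limit of > 50000 nM in this assay, at which 1 of the 3 values shown sits). So compound 3 sits at a limit, as compound 1 does, while compound 2 alone has a measured value.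

Compound 4 `COc1cc(-c2nn(-c3cccc(NC(=O)Nc4ccc(Cl)c(Cl)c4)c3)cc2-c2ccncc2)ccc1Cl` differs from compound 3 by (3,4-dichlorophenyl)amino in place of 3-(trifluoromethyl)phenyl on a carbonyl carbon. This change turns the amide back into a carbamoyl group, the kind of linkage compound 2 carries with its measured value 4310 nM. Compound 4 is therefore expected to become more toxic in this assay by a step of an at least 8.3-fold lower number from compound 3 to compound 4 (0.92 log units; beyond the scatter), clearly beyond the scatter. Compound 4 is estimated at 6000 nM, with a likely range from 1500 nM to 25000 nM.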

Compound 4, concentration lethal to 50% of the cells: > 50000 nM
Compound 4 was reported as a limit; the forecaster's own chance of this, stated with the estimate: 25%; middle value at least 8.3-fold (0.92 log units) away from the limit.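

Within the data shown here, compound 3 and compound 4 both stop at a limit of the test in this assay, so no step between them can be read. The compounds shown leave open whether (3,4-dichlorophenyl)amino in place of 3-(trifluoromethyl)phenyl on a carbonyl carbon changes toxicity at all.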